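A Single Methoxy Group Added to the Weaker Compound

A few compounds are considered here, and "the series" means these few. Any claim that something is new, unique, unknown or untested is made for them only; others in the source may bear on it.

Compounds 1 and 2 have both been tested in a functional assay on HepG2 cells (Homo sapiens) for cytotoxicity, read by MTT assay, with a stated time of 24 h; on this read-out lower numbers stand for stronger inhibition and higher numbers for weaker inhibition. Compound 1 `COc1cc(OC)c(C2CC(=O)c3cc(OC)c(OC)c(OC)c32)c(OC)c1` carries three methoxy groups on its pendant phenyl ring, and in this assay compound 1 gives 1490 nM. Compound 2 `COc1cc2c(c(OC)c1OC)C(c1ccccc1)CC2=O` has a bare phenyl ring on the same core, and in this assay compound 2 gives 188000 nM. Of the two numbers, compound 2 stands at the highest, meaning the weaker inhibition of cell growth, and the gap to compound 1 lies well beyond the usual scatter.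

Compound 3 `COc1cccc(C2CC(=O)c3cc(OC)c(OC)c(OC)c32)c1` has not yet been measured. It is made from compound 2 by methoxy in place of hydrogen on an aromatic carbon. This change moves compound 3 only part of the way toward the substitution seen on compound 1, so the expected step is a lowering of the number, of a size clearly beyond the scatter but short of the whole distance between compound 2 and compound 1. The step expected in this assay is a 3.8-fold lower number from compound 2 to compound 3 (0.58 log units; beyond the scatter). Compound 3 is therefore estimated to give 50000 nM in this assay, with a plausible range from 12000 nM to 160000 nM.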

Compound 3, half-maximal inhibitory concentration: >= 250000 nM
Compound 3: no number, only a limit; the forecaster's own chance of this, stated with the estimate: 5%; middle value at least 5.0-fold (0.69 log units) from the limit.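

In this assay compound 3 gives only a limit of the assay, >= 250000 nM, and not a true number. What can be read from this is an at least 1.3-fold higher number from compound 2 to compound 3 (0.12 log units; that floor lies within the scatter), so methoxy in place of hydrogen, placed on the phenyl ring meta to a large group, brings no lowering of the number that these data can show, and a single methoxy at this place is not enough on its own to give stronger inhibition of cell growth. How far the true number lies beyond this point stays unknown, and the reading cannot separate a flat step from a real loss, which leaves one plain fact to hold on to: the limit of >= 250000 nM in this assay, at which 1 of the 3 values shown sits.

The compounds shown leave open whether a single methoxy at another place on the phenyl ring would lower the number, or whether a lowering appears only when several methoxy groups sit on that ring together. They also leave open what a different group at this same place, such as a hydroxyl, an amine or a carboxylic acid, would do to the number in this assay.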